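Urea series: heteroaryl change at the benzyl ring

A few compounds are considered here, and "the series" means these few. Any claim that something is new, unique, unknown or untested is made for them only; others in the source may bear on it.

Measured so far:
compound 1 `Cc1cc(C)c(NC(=O)N(Cc2ccc(N3CCN(C)CC3)cc2)C2CCCCCC2)c(C)c1`, 57 nM
compound 2 `Cc1cc(C)c(NC(=O)N(Cc2ccc(-c3cc[nH]n3)cc2)C2CCCCCC2)c(C)c1`, 52 nM
compound 3 `Cc1cc(C)c(NC(=O)N(Cc2ccc(-c3cn[nH]c3)cc2)C2CCCCCC2)c(C)c1`, 270 nM

In an assay on microsomes from intestine for inhibition of acyl-CoA:cholesterol acyltransferase (Oryctolagus cuniculus) (a higher number here means a weaker inhibitor, a lower number a stronger inhibitor), compound 3 gives the highest number of the three. Compound 1 and compound 2 sit within the scatter of each other, shown by a 1.1-fold lower number from compound 1 to compound 2 (0.04 log units; within the scatter). Against both, compound 3 is clearly weaker: a 4.7-fold higher number from compound 1 to compound 3 (0.68 log units; beyond the scatter) and a 5.2-fold higher number from compound 2 to compound 3 (0.72 log units; beyond the scatter).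

Compound 4 `Cc1cc(C)c(NC(=O)N(Cc2ccc(-n3cncn3)cc2)C2CCCCCC2)c(C)c1` differs from compound 3 in one place: 1H-1,2,4-triazol-1-yl in place of 1H-pyrazol-4-yl on an aromatic carbon.

For the measured compounds named here, the steps that bear on this change are those into compound 3, both modest and both in the direction of a weaker inhibitor when the five-membered ring is joined through its 4-position. Going by the values given here, no measured step covers a ring joined through a nitrogen, nor one without a hydrogen-bond donor. Among the compounds with values here, the only guide is that the two other substituents at this position, in compound 1 and compound 2, gave numbers well below that of compound 3. Compound 4 is therefore expected to give a lower number than compound 3, the expected step being a 2.7-fold lower number from compound 3 to compound 4 (0.43 log units; beyond the scatter). The estimate for compound 4 in this assay is 100 nM, with a range from 35 nM to 300 nM.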

Compound 4, half-maximal inhibitory concentration: 26 nM
The estimate for compound 4 lay 3.8-fold (0.59 log units) above the measured number; the measured number lies below the stated range.
By their numbers in this assay, from the lowest: compounds 4, 2 and 1 (each within the scatter of the next, the first and the last beyond it); then compound 3.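

In this assay there is a 10-fold lower number from compound 3 to compound 4 (1.02 log units; beyond the scatter) as the large step here, so a five-membered aromatic ring para to a large group can go without the hydrogen-bond donor of the 1H-pyrazol-4-yl group. Against the other substituents, there is a 2.0-fold lower number from compound 2 to compound 4 (0.30 log units; within the scatter) that stays within the scatter, and a 2.2-fold lower number from compound 1 to compound 4 (0.34 log units; beyond the scatter) that lies beyond it, so the 1H-1,2,4-triazol-1-yl group matches the 1H-pyrazol-3-yl group and modestly exceeds the 4-methylpiperazin-1-yl group. No measurement shown accounts for the low potency of compound 3 against the other compounds.

The change from compound 3 to compound 4 alters the ring's point of attachment, its nitrogen count and its donor count together, so their separate contributions remain unresolved. Also open, as far as these compounds go, is how a 1H-imidazol-1-yl group, a morpholine or a carboxylic acid would behave at this position.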